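Changing one aryl group on compound 3

The source may hold more compounds than are shown below. What is called first, only, known or untested is meant among the compounds shown, and "the series" means these compounds.

In a functional assay on HeLa cells (Homo sapiens) for antiproliferative activity, read by MTT assay, with a stated time of 72 h (on this read-out higher numbers stand for weaker inhibition and lower numbers for stronger inhibition), compound 1 `CCNC(=O)c1cc(Oc2ccc(NC(=O)c3nn(-c4ccccc4OC(F)(F)F)c(=O)cc3C)cc2)ccn1` gives 3990 nM and compound 2 `CCNC(=O)c1cc(Oc2ccc(NC(=O)c3nn(-c4ccc(C)cc4)c(=O)cc3C)cc2)ccn1` gives 10700 nM. Compound 3 `CCCNC(=O)c1cc(Oc2ccc(NC(=O)c3nn(-c4ccc(Br)cc4F)c(=O)cc3C)cc2F)ccn1` gives 53500 nM, the highest number of the three and so the weakest inhibition. Compound 4 `CCCNC(=O)c1cc(Oc2ccc(NC(=O)c3nn(-c4cccc(C(F)(F)F)c4)c(=O)cc3C)cc2F)ccn1` differs from compound 3 in one group on an aromatic nitrogen: 3-(trifluoromethyl)phenyl in place of 4-bromo-2-fluorophenyl on an aromatic nitrogen. Among the measured compounds shown here, only one measured step bears on this change, a swap of group on an aromatic nitrogen: a 2.7-fold higher number from compound 1 to compound 2 (0.43 log units; beyond the scatter). That step is modest, and it comes from a different pair of groups. A similarly modest change is therefore expected in this assay, leaning towards a lower number because compound 3 at 53500 nM sits at the top. The expected step is a 1.8-fold lower number from compound 3 to compound 4 (0.25 log units; within the scatter). The estimate for compound 4 is 30000 nM, with an expected range from 10000 nM to 80000 nM.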

Compound 4, half-maximal inhibitory concentration: 8000 nM
Beside the measured number, compound 4's estimate is 3.8-fold (0.57 log units) above it; the whole stated range lies above it.
By their numbers in this assay, from the lowest: compounds 1, 4 and 2 (each within the scatter of the next, the first and the last beyond it); then compound 3.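

In this assay, putting 3-(trifluoromethyl)phenyl in place of 4-bromo-2-fluorophenyl on the aromatic nitrogen gives a 6.7-fold lower number from compound 3 to compound 4 (0.83 log units; beyond the scatter). The earlier step at this position involved other groups on a different pair of compounds, so this one shows that the aryl group also matters in the background shared by compound 3 and compound 4. Nothing measured here explains why the number falls.

From the compounds shown here alone, the bromine, the fluorine and the placement of the substituent all change at once, so their separate contributions remain open. Going by these compounds, how an amine or a carboxylic acid on this aryl ring would behave also remains open.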